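A few compounds are considered here, and "the series" means these few. Any claim that something is new, unique, unknown or untested is made for them only; others in the source may bear on it.

Measured compounds:
compound 1 `O=c1cc(-c2ccccc2)oc2ccc(OCCCCCCN3CCC(O)CC3)cc12` — 121 nM
compound 2 `O=c1cc(-c2ccccc2)oc2ccc(OCCCCCCN3CCCCC3)cc12` — 54 nM

In an assay on isolated protein (Cavia porcellus) with Sigma non-opioid intracellular receptor 1 (Homo sapiens) as the target, read by radioligand binding (a higher number here means a weaker inhibitor, a lower number a stronger inhibitor), compound 2 gives the lower of the two numbers, 54 nM. Among the compounds with values here, compound 1 gives 121 nM, and the single measured step is a 2.2-fold lower number from compound 1 to compound 2 (0.35 log units; beyond the scatter). Compound 3 `CCN(CC)CCCCCCOc1ccc2oc(-c3ccccc3)cc(=O)c2c1` differs from compound 2 by diethylamino in place of piperidin-1-yl on a saturated chain carbon, six bonds along the chain from an oxygen on an aromatic ring. Within the data shown here, no measured step alters the amine; the one step known concerns a hydroxy on the saturated ring and gives no guide here. The step of a 1.3-fold higher number from compound 2 to compound 3 (0.11 log units; within the scatter) is therefore expected to be small, direction uncertain, likely within the scatter. Compound 3 is estimated at 70 nM, range 25 nM to 200 nM.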

Compound 3, half-maximal inhibitory concentration: 100 nM
Estimate against measurement, compound 3: 1.4-fold (0.15 log units) below; the measured number falls inside the stated range.
By their numbers in this assay, from the lowest: compounds 2, 3 and 1 (each within the scatter of the next, the first and the last beyond it).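

In this assay, the amine at this place, on a saturated chain carbon six bonds along the chain from an oxygen on an aromatic ring, need not be a ring: diethylamino in place of piperidin-1-yl gives a 1.9-fold higher number from compound 2 to compound 3 (0.27 log units; within the scatter). Diethylamino in place of 4-hydroxypiperidin-1-y l gives a 1.2-fold lower number from compound 1 to compound 3 (0.08 log units; within the scatter), so compound 3 cannot be separated from either compound, although compound 1 and compound 2 stand apart.

Going by these compounds, whether dimethylamino, pyrrolidin-1-yl, morpholin-4-yl or a longer chain would read apart from these three remains open. No measurement offered here explains these readings.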